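Removing One Methoxy Group From a Cytotoxic Chalcone Series

The compounds below may be only part of what the source reports. "The series", "measured", "known", "first", "only" and "open" are said of these compounds alone.

Compound 1 `COc1cc(OC)c(OC)cc1/C=C/C(=O)c1ccccc1F`, compound 2 `COc1ccc(OC)c(/C=C/C(=O)c2ccccc2F)c1` and compound 3 `COc1ccc(C(=O)/C=C/c2ccc(OC)c(OC)c2OC)c(F)c1` were tested in a functional assay on HeLa cells (Homo sapiens) for cytotoxicity, read by MTT assay, with a stated time of 72 h; on this read-out lower numbers stand for stronger inhibition and higher numbers for weaker inhibition. In this assay compound 1 gives 293 nM, compound 2 gives 96.1 nM and compound 3 gives 211 nM. Compound 1 and compound 2 differ in a single place (hydrogen in place of methoxy on an aromatic carbon), and this change brought a 3.0-fold lower number from compound 1 to compound 2 (0.48 log units; beyond the scatter). Compound 3 and compound 1 have different cores; the difference between the two cores is not broken down here.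

Compound 4 `COc1ccc(C(=O)/C=C/c2ccc(OC)cc2OC)c(F)c1` is not yet measured. It differs from compound 3 in one place (hydrogen in place of methoxy on an aromatic carbon). The change is the same kind of change as that from compound 1 to compound 2, but the surroundings are not identical: in compound 1 the leaving methoxy sits ortho to a methoxy group, meta to a methoxy group and para to a large group, while in compound 3 it sits ortho to two methoxy groups and meta to a large group.

Among the measured compounds shown here, for compound 4 a step of a 1.8-fold lower number from compound 3 to compound 4 (0.25 log units; within the scatter) in this assay is expected, somewhat smaller than the earlier step from compound 1 to compound 2, because a 3.0-fold lower number from compound 1 to compound 2 (0.48 log units; beyond the scatter) was seen at a differently placed methoxy and only one such step is known. Compound 4 is therefore estimated at 120 nM, with a likely range from 55 nM to 300 nM.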

Compound 4, half-maximal inhibitory concentration: 260 nM
For compound 4 the middle estimate is 2.2-fold (0.34 log units) below the measured one; the range from low to high includes it.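

In this assay, replacing the methoxy group with hydrogen on the core of compound 3 gave a 1.2-fold higher number from compound 3 to compound 4 (0.09 log units; within the scatter), so this step cannot be told apart from the ordinary variation between repeated measurements. Set beside the earlier result, the same replacement did not carry over with the same size from one core to the other: the same change on two cores in this assay, a 3.0-fold lower number (0.48 log units; beyond the scatter) from compound 1 to compound 2 and a 1.2-fold higher number (0.09 log units; within the scatter) from compound 3 to compound 4, 3.8-fold (0.57 log units) apart, beyond the scatter of two such steps. This shows that a step seen on one core in this series cannot simply be transferred to another, but it does not show why: the two pairs differ in their cores and also in the surroundings of the methoxy group that leaves, and two pairs cannot separate those differences or give a rule for the whole series.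

The compounds shown leave open what would happen if the methoxy group at either place were replaced by something other than hydrogen, such as a hydroxyl group, an amine or a longer ether chain. They also leave open whether removing the same methoxy group from a third core would follow the step from compound 1 to compound 2, the step from compound 3 to compound 4, or neither.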